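Swapping the Indolyl Arm of Compound 1 for Phenyl

A few compounds are considered here, and "the series" means these few. Any claim that something is new, unique, unknown or untested is made for them only; others in the source may bear on it.

Within the data shown here, compound 1 `COc1cc(-c2ccnc3cc(-c4ccc5cc[nH]c5c4)nn23)cc(OC)c1OC` is the only member of this set that returns a number: in a functional assay on MCF7 cells (Homo sapiens) for inhibition, read by CCK-8 assay, with a stated time of 48 h (a higher number here means a weaker inhibitor, a lower number a stronger inhibitor), compound 1 gives 23 nM. Compound 2 `COc1cc(-c2ccnc3c(-c4ccc(C)cc4)cnn23)cc(OC)c1OC` reaches only a limit of the assay, > 10000 nM. Compound 3 `Cc1ccc(-c2cc3nccc(-c4ccc(F)cc4)n3n2)cc1` likewise stops at a limit, > 10000 nM. Among the measured compounds shown here, the picture is therefore dominated by the limit of > 10000 nM in this assay, at which 2 of the 3 values shown sit, and no step between two measured compounds is available to calibrate a change. Compound 4 `COc1cc(-c2ccnc3cc(-c4ccccc4)nn23)cc(OC)c1OC` has not yet been measured. It differs from compound 1 by phenyl in place of 1H-indol-6-yl on an aromatic carbon. In this assay a loss beyond the usual scatter is expected, estimated as a 13-fold higher number from compound 1 to compound 4 (1.12 log units; beyond the scatter). Compound 4 is accordingly expected to give about 300 nM, within a range from 50 nM to 3000 nM.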

Compound 4, half-maximal inhibitory concentration: 254 nM
Compound 4: middle estimate off by 1.2-fold (0.07 log units), on the high side; the range from low to high includes it.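

Among these compounds, the swap of 1H-indol-6-yl for phenyl on this aromatic carbon gives the first calibrated step in this assay: an 11-fold higher number from compound 1 to compound 4 (1.04 log units; beyond the scatter). The arm at this position therefore matters beyond the scatter, yet compound 4 still returns a number, so phenyl here does not reach the value where much of the set sits: the limit of > 10000 nM in this assay, at which 2 of the 4 values shown sit.

On these data alone, what stays open is whether the step follows the indolyl's ring nitrogen hydrogen or its five-membered ring. A naphthyl or an aminophenyl group on this carbon would separate those two readings.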